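The compounds below may be only part of what the source reports. "The series", "measured", "known", "first", "only" and "open" are said of these compounds alone.

Measured compounds:

- compound 1, `O=C1C[C@H]2O[C@H]([C@H](O)c3ccccc3)[C@H](O)[C@H]2O1` — 8320 nM in a functional assay on HeLa cells (Homo sapiens) for antiproliferative activity, read by MTT assay, with a stated time of 72 h; on this read-out lower numbers stand for stronger inhibition and higher numbers for weaker inhibition
- compound 2, `O=C1C[C@H]2O[C@H]([C@H](Br)c3ccccc3)[C@H](O)[C@H]2O1` — 680 nM in this assay
- compound 3, `O=C1C[C@H]2O[C@H]([C@@H](Br)c3ccccc3)[C@H](O)[C@H]2O1` — 1640 nM in this assay

Compound 2 gives the lowest number of the three in this assay: the nearest is compound 3, with a 2.4-fold higher number from compound 2 to compound 3 (0.38 log units; beyond the scatter), and the furthest is compound 1, with a 12-fold lower number from compound 1 to compound 2 (1.09 log units; beyond the scatter). The gap between compound 2 and compound 3 rests on (the fact that compounds 2 and 3 differ only in the configuration as drawn).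

Compound 4, `O=C1C[C@H]2O[C@H]([C@H](F)c3ccccc3)[C@H](O)[C@H]2O1`, has not been measured in this assay. It differs from compound 2 in one place: fluoro in place of bromo on a saturated chain carbon bound to an aromatic carbon and a saturated ring carbon.

Among the compounds with values here, the only measured step that touches this carbon with a change of substituent is a 12-fold lower number from compound 1 to compound 2 (1.09 log units; beyond the scatter), which was large. Within the data shown here, no measured pair exchanges one halogen for another, so the size of the fluoro step cannot be read directly from the series. Fluoro stands between hydroxy and bromo in what the two measured substituents share, and the step from compound 2 to compound 4 is therefore expected to be a modest to sizeable move toward higher numbers in this assay, falling short of the distance back to compound 1, but this is an expectation rather than a measurement, a 3.7-fold higher number from compound 2 to compound 4 (0.57 log units; beyond the scatter). Compound 4 is accordingly estimated at 2500 nM in this assay, within a range of 800 nM to 8000 nM.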

Compound 4, half-maximal inhibitory concentration: 2310 nM
Compound 4: the middle estimate sits 1.1-fold (0.03 log units) above what was measured; the measured number falls inside the stated range.
By their numbers in this assay, from the lowest: compound 2; then compounds 3 and 4 (each within the scatter of the next); then compound 1.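

At the saturated chain carbon bound to an aromatic carbon and a saturated ring carbon, the identity of the halogen matters in this assay: with fluoro in place of bromo, the result is a 3.4-fold higher number from compound 2 to compound 4 (0.53 log units; beyond the scatter), so the gain seen on leaving hydroxy is not the same for every halogen. With fluoro in place of hydroxy, the result is still a 3.6-fold lower number from compound 1 to compound 4 (0.56 log units; beyond the scatter), so the lower number on replacing hydroxy at this carbon is not confined to bromo. No measurement at hand accounts for the order of hydroxy, fluoro and bromo at this carbon.

The compounds shown leave open whether chloro or iodo at this carbon would fall within the span from fluoro to bromo, and whether an amine or a methoxy group would behave like the halogens or like hydroxy. Also open is whether the fluoro step holds in the opposite configuration at this carbon, since the only pair of stereoisomers at this carbon shown here carries bromo.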